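The source may report more compounds than this note shows. Statements on the series, on what has been measured and on what is new or still open speak of the compounds shown alone.

In a functional assay for inhibition, with Homo sapiens as the target (on this read-out lower numbers stand for stronger inhibition and higher numbers for weaker inhibition), three sulfonamides built on one shared core have been measured. Compound 1 `CS(=O)(=O)N[C@@H](CNC(=O)c1ccc2c(c1)C(=O)N(CCC1CCNCC1)C2)C(=O)O`, with methyl on the sulfonyl sulfur, gives 14 nM. Compound 2 `CCCCS(=O)(=O)N[C@@H](CNC(=O)c1ccc2c(c1)C(=O)N(CCC1CCNCC1)C2)C(=O)O`, with a butyl chain there, gives 14 nM; 9 nM (2 entries), and the several entries of compound 2 in this assay, 14 nM; 9 nM (2 entries) shows how far repeat entries of a single compound can lie apart. Compound 3 `O=C(NC[C@H](NS(=O)(=O)c1ccccc1)C(=O)O)c1ccc2c(c1)C(=O)N(CCC1CCNCC1)C2`, with phenyl at that place, gives 8 nM, which stands within the scatter of compound 1 and is the nearest comparison available. Compound 4 `O=C(NC[C@H](NS(=O)(=O)c1cccnc1)C(=O)O)c1ccc2c(c1)C(=O)N(CCC1CCNCC1)C2` has pyridin-3-yl in place of phenyl on a sulfonyl sulfur. For the measured compounds named here, the one measured step at this place is a 1.8-fold lower number from compound 1 to compound 3 (0.24 log units; within the scatter), so even the exchange of methyl for a whole aromatic ring left the number essentially unmoved. A swap of one aromatic ring for another is therefore expected to do no more than that. The estimated change is a 1.3-fold higher number from compound 3 to compound 4 (0.10 log units; within the scatter), with no shift beyond the scatter expected in either direction. Compound 4 is expected at about 10 nM, with an estimated range from 4 nM to 25 nM.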

Compound 4, half-maximal inhibitory concentration: 15 nM
Beside the measured number, compound 4's estimate is 1.5-fold (0.18 log units) below it, within the range that was stated.
By their numbers in this assay, from the lowest: compounds 3, 1 and 4 (each within the scatter of the next).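

Replacing the carbon-only ring with pyridin-3-yl, which adds a ring nitrogen and a hydrogen-bond acceptor on the sulfonyl sulfur, gives a 1.9-fold higher number from compound 3 to compound 4 (0.27 log units; within the scatter) in this assay, so this change of ring does not shift the number beyond the scatter. Set against the small methyl group, the same ring gives a 1.1-fold higher number from compound 1 to compound 4 (0.03 log units; within the scatter), so methyl, phenyl and pyridin-3-yl at this place cannot be told apart on this read-out. Steps of this size are no larger than the spread seen between repeat entries of a single compound: the several entries of compound 2 in this assay, 14 nM; 9 nM (2 entries)

The compounds shown leave open whether any group on the sulfonyl sulfur can move the number beyond the scatter in either direction. A phenyl ring carrying an amine or a carboxylic acid, or a chain longer than butyl, would test how far this insensitivity extends.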